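Shortening the amine's reach: from dimethylamino to propylamino

The source may report more compounds than this note shows. Statements on the series, on what has been measured and on what is new or still open speak of the compounds shown alone.

compound 1 `CCN[C@@H]1CC[C@H](NC(=O)CNC(=O)c2cccc(C(F)(F)F)c2)C[C@@H]1CS(=O)(=O)c1ccccc1`: 25%
compound 2 `CN(C)[C@@H]1CC[C@H](NC(=O)CNC(=O)c2cccc(C(F)(F)F)c2)C[C@@H]1CS(=O)(=O)c1ccccc1`: 4.3%

For the measured compounds named here, in an ADME assay on microsomes from liver (Mus musculus) for metabolic stability, with a stated time of 10 min (a higher number here means that more of the compound is left, a lower number that less of the compound is left), compound 2 gives 4.3%, the lower of the two numbers measured so far. The unmeasured compound 3 `CCCN[C@@H]1CC[C@H](NC(=O)CNC(=O)c2cccc(C(F)(F)F)c2)C[C@@H]1CS(=O)(=O)c1ccccc1` differs from it in one group on the shared core: propylamino in place of dimethylamino on a saturated ring carbon. Going by the values given here, only one measured step bears on this change: a number 20.7 percentage points lower from compound 1 to compound 2 (beyond the scatter), where dimethylamino took the place of ethylamino on that ring carbon. Compound 3 goes the opposite way, since its propylamino group is a closer relative of the ethylamino group of compound 1, which gave 25%. A rise is therefore expected. The longer chain has not been tested, however, and a single step is thin evidence, so the rise may not reach the full size of that earlier step. The expected step is a number 13.7 percentage points higher from compound 2 to compound 3 (beyond the scatter). Compound 3 is estimated at 18%, with an expected range from 6% to 36%.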

Compound 3, percent of the compound remaining: 28%
For compound 3 the middle estimate is 10 percentage points below the measured one; the range from low to high includes it.
By their numbers in this assay, from the lowest: compound 2; then compounds 1 and 3 (each within the scatter of the next).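

In this assay, putting propylamino in place of dimethylamino on this saturated ring carbon gives a number 23.7 percentage points higher from compound 2 to compound 3 (beyond the scatter), so a second amine with one chain on its nitrogen stands well apart from dimethylamino, as ethylamino did in a number 20.7 percentage points lower from compound 1 to compound 2 (beyond the scatter). The added methyl on the chain gives a number 3 percentage points higher from compound 1 to compound 3 (within the scatter), so at this position ethylamino and propylamino cannot be told apart in this read-out, and among these three compounds only dimethylamino stands apart. Nothing available explains why the numbers fall this way, and the three values alone describe the pattern without accounting for it.

The compounds shown leave open how far this tolerance of chain length runs, since butylamino on the longer side and methylamino or the plain unsubstituted amine on the shorter side could each fall in the same range or leave it. They also leave open whether the step depends on having two groups on the nitrogen or on dimethylamino alone, a question that diethylamino or a pyrrolidine ring at this carbon would address.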